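From 3-chlorophenyl to 2-bromophenyl in the series

The source may report more compounds than this note shows. Statements on the series, on what has been measured and on what is new or still open speak of the compounds shown alone.

In a functional assay on PC-3 cells (Homo sapiens) for inhibition, read by MTT assay, with a stated time of 48 h, tested at 10 uM (on this read-out higher numbers stand for more inhibition of growth at the one concentration tested and lower numbers for less inhibition of growth), compound 2 (`Cc1oc2c([C@H]3CCN(C)C[C@H]3O)c(O)cc(O)c2c(=O)c1C(O)c1cccc(Cl)c1`) gives 31%, level within the scatter with compound 1 (`Cc1oc2c([C@H]3CCN(C)C[C@H]3O)c(O)cc(O)c2c(=O)c1C(O)c1ccc([N+](=O)[O-])cc1`) at 24%. Compound 3 (`Cc1oc2c([C@H]3CCN(C)C[C@H]3O)c(O)cc(O)c2c(=O)c1C(O)c1ccccc1Br`) differs from compound 2 by 2-bromophenyl in place of 3-chlorophenyl on a saturated chain carbon bound to an aromatic carbon and an oxygen on a saturated carbon. Going by the values given here, the one measured step at this place is a number 7 percentage points higher from compound 1 to compound 2 (within the scatter). Among the compounds with values here, with only that step as a guide, no change beyond the scatter is expected in this assay, and the estimated step is a number 2 percentage points lower from compound 2 to compound 3 (within the scatter). The expected value for compound 3 is 29%, with an estimated range of 14% to 45%.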

Compound 3, percent growth inhibition at one concentration: 45%
For compound 3 the middle estimate is 16 percentage points below the measured one; measured number inside the range.
By their numbers in this assay, from the lowest: compounds 1 and 2 (each within the scatter of the next); then compound 3.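

The aryl group on the saturated chain carbon can move growth inhibition beyond the scatter in this assay and the 2-bromophenyl group does so on both comparisons, with a number 14 percentage points higher from compound 2 to compound 3 (beyond the scatter) and a number 21 percentage points higher from compound 1 to compound 3 (beyond the scatter) as the steps. Compound 1 and compound 2 alone showed no such separation at this position. No available measurement bears on the reason for this change.

From the compounds shown here alone, compound 2 and compound 3 differ in both the halogen and its position on the phenyl ring, so the contribution of each remains open. A 2-chlorophenyl or 3-bromophenyl group would separate the two.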